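This account rests on a few compounds, and the source may have more. Where it says the series, first, only, none or still open, it means among the compounds named here.

Among the measured compounds shown here, in a functional assay on HT-29 cells (Homo sapiens) for inhibition, read by sulforhodamine B assay, with a stated time of 48 h, tested at 10 uM (a higher number here means a weaker effect of the compound at the concentration tested, a lower number a stronger effect), compound 2 `COc1cc2cc(Oc3ccc(NC(=O)Nc4ccc(C)cc4)cc3)c(C)nc2cc1OC` gives 115%, the higher of the two numbers measured so far; the only neighbour is compound 1 `COc1cc2cc(Oc3ccc(NC(=O)Nc4ccccc4)cc3)c(C)nc2cc1OC`, which in this assay gives 48.9%. For the measured compounds named here, the one measured step, a number 66.1 percentage points higher from compound 1 to compound 2 (beyond the scatter), runs between these two compounds, and it is large. Compound 3 `COc1cc2cc(Oc3ccc(NC(=O)Nc4cccc(C(F)(F)F)c4)cc3)c(C)nc2cc1OC` has not yet been measured in this assay. It differs from compound 2 in the change (3-(trifluoromethyl)phenyl in place of 4-methylphenyl on an amide-type nitrogen), a swap of one substituted ring for another on an amide-type nitrogen. The measured step speaks only to a methyl against hydrogen on that ring, so it bears on the present change only loosely. Since compound 2 already stands at the weak end of the two numbers, an expected step of a number 30 percentage points lower from compound 2 to compound 3 (beyond the scatter) seems reasonable, with wide uncertainty. Compound 3 is therefore estimated at 85%, with a range from 45% to 120%.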

Compound 3, a percentage reported as activity, at one concentration (the size of the read-out at that concentration, not a potency): 6.56%
Estimate against measurement, compound 3: 78.4 percentage points above, and the stated range ends above it.
By their numbers in this assay, from the lowest: compound 3; then compound 1; then compound 2.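

In this assay, the ring on the amide-type nitrogen can move the read-out in either direction, not only towards a weaker effect as the methyl step suggested. Trifluoromethyl in place of hydrogen gives a number 42.3 percentage points lower from compound 1 to compound 3 (beyond the scatter), so this substitution strengthens the effect relative to the unsubstituted phenyl, the opposite direction to methyl. The swap of 4-methylphenyl for 3-(trifluoromethyl)phenyl gives a number 108.4 percentage points lower from compound 2 to compound 3 (beyond the scatter), which shows how strongly the read-out depends on the choice of substituted ring, and compound 3 has the lowest number of the three.

As far as these compounds go, whether the gain belongs to the trifluoromethyl group itself or to its place on the ring stays open, as does how a chlorine atom, a methoxy group or a nitrile on that ring would read. No measurement at hand explains the differences among these compounds.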